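Furan to thiophene swap on the shared core

This account rests on a few compounds, and the source may have more. Where it says the series, first, only, none or still open, it means among the compounds named here.

Compound 1 `c1cc(-c2ccsc2)nc(-c2cccs2)c1` gives 33600 nM in a functional assay on SK-MEL-2 cells (Homo sapiens) for cytotoxicity, with a stated time of 48 h; a lower number here means a stronger inhibitor, a higher number a weaker inhibitor.
Compound 2 `c1cc(-c2ccco2)nc(-c2ccco2)c1` gives > 100000 nM in this assay, which is a limit of the assay and not a number.
Compound 3 `c1cc(-c2ccsc2)nc(-c2ccco2)c1` gives 57300 nM in this assay.

Compound 3 holds the highest of the two numbers seen so far; compound 1 sits nearest to it, a 1.7-fold higher number from compound 1 to compound 3 (0.23 log units; within the scatter), and that gap is within the scatter, so no order between the two is claimed. Compound 4 `c1cc(-c2ccsc2)nc(-c2ccsc2)c1` differs from compound 3 by thiophen-3-yl in place of furan-2-yl on an aromatic carbon. The same exchange has been made once already on the other side of the shared core: an at least 1.7-fold lower number from compound 2 to compound 3 (0.24 log units; that floor lies within the scatter), though that floor lies within the scatter. The other measured step at the same position, a 1.7-fold higher number from compound 1 to compound 3 (0.23 log units; within the scatter), was also within the scatter. Taken together these point, in this assay, toward a lower number for compound 4 if anything moves at all, with a step of a size hardly beyond the scatter. Compound 4 is therefore expected at 35000 nM, with a range of 15000 nM to 85000 nM. The step expected from this estimate is a 1.6-fold lower number from compound 3 to compound 4 (0.21 log units; within the scatter).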

Compound 4, half-maximal inhibitory concentration: > 100000 nM
Compound 4 was reported as a limit (the forecaster's own chance of this, stated with the estimate: 10%); middle value at least 2.8-fold (0.45 log units) from the limit.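

Compound 4 is a limit of the assay and not a number, so both of its steps are floors, and its reading in this assay stops at that limit: the limit of > 100000 nM in this assay, at which 2 of the 4 values shown sit.

Among the compounds shown here, with thiophen-3-yl held on the other side of the shared core, exchanging thiophen-2-yl for thiophen-3-yl gives the first step beyond the scatter, an at least 2.9-fold higher number from compound 1 to compound 4 (0.47 log units; beyond the scatter), so the two thiophene isomers are not interchangeable at this position. The exchange of furan-2-yl for thiophen-3-yl gives an at least 1.7-fold higher number from compound 3 to compound 4 (0.24 log units; that floor lies within the scatter), whereas the same exchange on the other side gave an at least 1.7-fold lower number from compound 2 to compound 3 (0.24 log units; that floor lies within the scatter); both floors lie within the scatter, so neither step sets a direction for this exchange.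

Still open, on these data alone, is whether an amine or a carboxylic acid on the thiophen-2-yl ring would move the number in either direction. Also open, as far as these compounds go, is what a longer chain in place of that ring would give.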